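Methoxy for methylamino on a diarylurea core

A few compounds are considered here, and "the series" means these few. Any claim that something is new, unique, unknown or untested is made for them only; others in the source may bear on it.

Compound 1: `O=C(Nc1ccc(-n2ncc3c(Br)cccc32)cc1)Nc1ccc(Cl)c(C(F)(F)F)c1` gives 4000 nM. Compound 2: `CNc1cccc2c1cnn2-c1ccc(NC(=O)Nc2ccc(Cl)c(C(F)(F)F)c2)cc1` gives 5900 nM.

In a functional assay on HT-29 cells (Homo sapiens) for cytotoxicity, read by MTT assay, with a stated time of 72 h (on this read-out higher numbers stand for weaker inhibition and lower numbers for stronger inhibition), compound 2 stands highest of the two numbers, but the gap to compound 1 is small: a 1.5-fold higher number from compound 1 to compound 2 (0.17 log units; within the scatter). Compound 3, `COc1cccc2c1cnn2-c1ccc(NC(=O)Nc2ccc(Cl)c(C(F)(F)F)c2)cc1`, differs from compound 2 by methoxy in place of methylamino on an aromatic carbon. For the measured compounds named here, only the step from compound 1 to compound 2 bears on this change, and it stayed within the scatter, so no movement beyond the scatter is expected in this assay. Compound 3 is therefore expected near compound 2, with an estimated 1.2-fold lower number from compound 2 to compound 3 (0.07 log units; within the scatter), giving about 5000 nM, in the range 2000 nM to 15000 nM.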

Compound 3, half-maximal inhibitory concentration: > 32000 nM
Compound 3 ended at the assay's limit; the forecaster's own chance of this, stated with the estimate: 5%; at least 6.4-fold (0.80 log units) between middle value and limit.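

In this assay this position proved sensitive to the group it carries: bromo and methylamino lie within the scatter of each other, yet methoxy brought an at least 5.4-fold higher number from compound 2 to compound 3 (0.73 log units; beyond the scatter) and an at least 8.0-fold higher number from compound 1 to compound 3 (0.90 log units; beyond the scatter) on this read-out. The methoxy and methylamino groups have the same heavy-atom count, so that count alone does not set the outcome here. Compound 3 stands at a limit of the assay, not at a number: the limit of > 32000 nM in this assay, at which 1 of the 3 values shown sits.

Going by these compounds, how far compound 3 lies past that limit remains open. So does whether ethoxy, hydroxyl or dimethylamino at this carbon would behave like methoxy or like methylamino.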